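Benzyl substituent variation on the dithiocarbamate-triazole series

This account rests on a few compounds, and the source may have more. Where it says the series, first, only, none or still open, it means among the compounds named here.

Compound 2 `O=C(OCc1ccccc1)N1CCN(C(=S)SCc2cn(Cc3ccc(F)cc3)nn2)CC1` sits in the middle of the three measured compounds in a functional assay on MGC-803 cells (Homo sapiens) for inhibition, read by MTT assay, with a stated time of 72 h; a lower number here means a stronger inhibitor, a higher number a weaker inhibitor: compound 2 gives 17600 nM. Compound 1 `CC(C)(C)OC(=O)N1CCN(C(=S)SCc2cn(Cc3ccc(Cl)cc3)nn2)CC1` gives 9790 nM, which lies within the scatter of compound 2. Compound 3 `Cc1ccc(-n2cc(CSC(=S)N3CCN(C(=O)OC(C)(C)C)CC3)nn2)cc1` gives 48300 nM, which lies beyond the scatter of compound 2.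

Compound 4 `O=C(OCc1ccccc1)N1CCN(C(=S)SCc2cn(Cc3ccc(Cl)c(Cl)c3)nn2)CC1` differs from compound 2 by 3,4-dichlorophenyl in place of 4-fluorophenyl on a saturated chain carbon bound to an aromatic nitrogen. Among the measured compounds shown here, no measured step covers this exact change. For the measured compounds named here, the only step at this part of the core is a 4.9-fold higher number from compound 1 to compound 3 (0.69 log units; beyond the scatter), which exchanges a benzyl for a directly attached aryl and so is not a clean guide. Between compound 1 and compound 2 the 4-chlorobenzyl and 4-fluorobenzyl compounds, with different carbamates, lie within the scatter of each other.

On this basis a change of no more than the scatter is expected, with a slight lean toward a lower number; the step of a 1.5-fold lower number from compound 2 to compound 4 (0.17 log units; within the scatter) is the estimate. Compound 4 is therefore expected at 12000 nM, with a range from 5000 nM to 35000 nM.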

Compound 4, half-maximal inhibitory concentration: 7140 nM
Compound 4: the middle estimate sits 1.7-fold (0.23 log units) above what was measured; the measured number falls inside the stated range.
By their numbers in this assay, from the lowest: compounds 4, 1 and 2 (each within the scatter of the next, the first and the last beyond it); then compound 3.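

In this assay, 3,4-dichlorophenyl in place of 4-fluorophenyl on a saturated chain carbon bound to an aromatic nitrogen gives a 2.5-fold lower number from compound 2 to compound 4 (0.39 log units; beyond the scatter) with the rest of the structure unchanged. The earlier step at this part of the core, a 4.9-fold higher number from compound 1 to compound 3 (0.69 log units; beyond the scatter), also removed the benzyl link, whereas this one shows that changing only the aryl group on the chain carbon can move the number beyond the scatter. Nothing available explains this step.

The compounds shown do not separate the effect of adding a second chlorine from that of losing fluorine, since 4-chlorobenzyl is not paired with 3,4-dichlorobenzyl on the same carbamate. On these data alone, how an amine, a carboxylic acid or a longer chain at this place would read in this assay also remains open.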